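The compounds below may be only part of what the source reports. "The series", "measured", "known", "first", "only" and "open" are said of these compounds alone.

Measured so far:
Compound 1 `CC(=O)c1ccc(NCc2cncn2Cc2ccc(-c3ccccc3)cc2)cc1-c1ccccc1` — > 10000 nM
Compound 2 `COC(=O)c1ccc(NCc2cncn2Cc2ccc(N)cc2)cc1-c1ccccc1` — > 10000 nM
Compound 3 `Cc1ccccc1-c1cccc(NCc2cncn2Cc2ccccc2)c1` — > 1000 nM

All three were tested in a toxicity assay on NIH3T3 cells (Mus musculus) for cytotoxicity, read by resazurin assay; a higher number here means that more compound is needed for the effect, a lower number that less compound is needed. For compound 1 the value > 10000 nM is a limit of the assay, not a number. For compound 2 the value > 10000 nM is likewise a limit, and it shares the limit of > 10000 nM in this assay, at which 2 of the 3 values shown sit, with compound 1. For compound 3 the value > 1000 nM is also a limit, (the limit of > 1000 nM in this assay, at which 1 of the 3 values shown sits). So compound 2 stands at the upper edge of what this assay reports, and no ranking among the three is possible.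

Compound 4 `COC(=O)c1ccc(NCc2cncn2Cc2ccccc2C#N)cc1-c1ccccc1` has not yet been measured. It differs from compound 2 in one place: 2-cyanophenyl in place of 4-aminophenyl on a saturated chain carbon bound to an aromatic nitrogen. Within the data shown here, no pair of measured compounds differs in a single place, so no measured step guides the size of this change. Since all three measured values are limits, the step from compound 2 to compound 4 is expected to be none beyond the scatter, a step that the limit leaves unreadable from compound 2 to compound 4. Compound 4 is expected to give about 15000 nM in this assay, within 5000 nM to 50000 nM, most likely reported again only as a limit.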

Compound 4, half-maximal effective concentration: 25000 nM
Estimate against measurement, compound 4: 1.7-fold (0.22 log units) below, within the range that was stated.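

In this assay compound 2 gives > 10000 nM, a limit of the assay and not a number, so no step to compound 4 can be read: the limit of > 10000 nM in this assay, at which 2 of the 4 values shown sit.

The compounds shown leave open whether 2-cyanophenyl in place of 4-aminophenyl changes the result in this assay at all.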